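A methyl moves: what to expect for compound 4

This account rests on a few compounds, and the source may have more. Where it says the series, first, only, none or still open, it means among the compounds named here.

Compound 1, `Fc1ccccc1/C=C/c1nnc(-c2ccc3c(c2)OCCO3)o1`: 402000 nM
Compound 2, `Brc1cccc(/C=C/c2nnc(-c3ccc4c(c3)OCCO4)o2)c1`: 322000 nM
Compound 3, `Cc1cccc(/C=C/c2nnc(-c3ccc4c(c3)OCCO4)o2)c1`: 201000 nM

In an ADME assay on HUVEC cells (Homo sapiens) for cytotoxicity, read by MTT assay, with a stated time of 24 h (a higher number here means that more compound is tolerated, a lower number that less compound is tolerated), compound 3 has the lowest of the three numbers, yet both gaps stay within the scatter: a 1.6-fold lower number from compound 2 to compound 3 (0.20 log units; within the scatter) and a 2.0-fold lower number from compound 1 to compound 3 (0.30 log units; within the scatter). Compound 4, `Cc1ccccc1/C=C/c1nnc(-c2ccc3c(c2)OCCO3)o1`, has not been measured. It differs from compound 3 in one place: 2-methylphenyl in place of 3-methylphenyl on a double-bonded chain carbon bound to a double-bonded chain carbon. Among the measured compounds shown here, no measured step moves a methyl from one ring position to another; the three steps that bear on the change are all swaps of the aryl group or its substituent, and each was within the scatter, including a 1.2-fold lower number from compound 1 to compound 2 (0.10 log units; within the scatter). Compound 4 is therefore expected to show no step beyond the scatter, a 1.2-fold higher number from compound 3 to compound 4 (0.09 log units; within the scatter). The estimate for compound 4 is 250000 nM, within 120000 nM to 500000 nM.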

Compound 4, half-maximal cytotoxic concentration: 356000 nM
Estimate against measurement, compound 4: 1.4-fold (0.15 log units) below; measured number inside the range.
By their numbers in this assay, from the lowest: compounds 3, 2, 4 and 1 (each within the scatter of the next).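

In this assay the change from 3-methylphenyl to 2-methylphenyl gives a direct reading of where the methyl sits on this ring, and a 1.8-fold higher number from compound 3 to compound 4 (0.25 log units; within the scatter) shows that the move stays within the scatter. The step to the bromo compound gives a 1.1-fold higher number from compound 2 to compound 4 (0.04 log units; within the scatter) and the step from the fluoro compound gives a 1.1-fold lower number from compound 1 to compound 4 (0.05 log units; within the scatter) and so neither separates these compounds. No evidence is available to explain these steps. Still open, going by these compounds, is whether an amine or a carboxylic acid on this phenyl ring, or a longer chain in place of the methyl, would give a step beyond the scatter.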